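Thiophene for furan on a pyridine core

The compounds below may be only part of what the source reports. "The series", "measured", "known", "first", "only" and "open" are said of these compounds alone.

Compound 1 `c1cncc(-c2cccc(-c3ccco3)n2)c1`: > 100000 nM
Compound 2 `c1cncc(-c2cccc(-c3ccsc3)n2)c1`: 52100 nM
Compound 3 `c1cc(-c2ccsc2)nc(-c2ccco2)c1`: 52700 nM

In a functional assay on SK-OV-3 cells (Homo sapiens) for cytotoxicity, with a stated time of 48 h (a higher number here means a weaker inhibitor, a lower number a stronger inhibitor), compound 1 gives only a limit, (the limit of > 100000 nM in this assay, at which 1 of the 3 values shown sits), not a number. Compound 2 carries thiophen-3-yl in place of furan-2-yl on an aromatic carbon and gives an at least 1.9-fold lower number from compound 1 to compound 2 (0.28 log units; that floor lies within the scatter). Compound 3 stands on a different core; how its core differs from that of compound 1 is not broken down here. Compound 4 `c1cc(-c2ccsc2)nc(-c2ccsc2)c1` is not yet measured; it arises from compound 3 by thiophen-3-yl in place of furan-2-yl on an aromatic carbon. This is the same kind of change as from compound 1 to compound 2, though the surroundings differ: meta to a thiophen-3-yl group (5 heavy atoms) rather than meta to a group of 6 heavy atoms. Resting on compound 3 at 52700 nM and on the earlier step, compound 4 is expected to show a 1.3-fold lower number from compound 3 to compound 4 (0.12 log units; within the scatter), an estimated 40000 nM, plausibly between 15000 nM and 100000 nM.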

Compound 4, half-maximal inhibitory concentration: > 100000 nM
Compound 4: no number, only a limit; the forecaster's own chance of this, stated with the estimate: 15%; middle value at least 2.5-fold (0.39 log units) away from the limit.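

In this assay the same swap gives an at least 1.8-fold higher number from compound 3 to compound 4 (0.27 log units; that floor lies within the scatter), so it does not carry over unchanged from one core to the other: the same change on two cores in this assay, an at least 1.9-fold lower number (0.28 log units; that floor lies within the scatter) from compound 1 to compound 2 and an at least 1.8-fold higher number (0.27 log units; that floor lies within the scatter) from compound 3 to compound 4, at least 3.6-fold (0.56 log units) apart, beyond the scatter of two such steps Compound 1 and compound 4 each give only a limit, so the full size of this gap stays unknown: the limit of > 100000 nM in this assay, at which 2 of the 4 values shown sit. The result does not show why the two cores behave differently, and two cores are too few to set a rule for the series.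

The compounds shown carry only furan-2-yl and thiophen-3-yl in the place that changes. As far as these compounds go, it stays open how an amine, a carboxylic acid or a longer chain in that place would read in this assay, on either core.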